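Compound 4 Expected After Swapping the Aryl Group on Compound 3

The source may report more compounds than this note shows. Statements on the series, on what has been measured and on what is new or still open speak of the compounds shown alone.

Measured so far:
compound 1 `CCN(Cc1ccncc1)C(=S)SCc1ccc(C(=O)Nc2ccccc2N)cc1` — 63.5%
compound 2 `Nc1ccccc1NC(=O)c1ccc(CSC(=S)N2CCc3ccc([N+](=O)[O-])cc32)cc1` — 45.7%
compound 3 `COc1ccc(N2CCN(C(=S)SCc3ccc(C(=O)Nc4ccccc4N)cc3)CC2)cc1` — 39.4%

In a functional assay on HeLa cells (Homo sapiens) for antiproliferative activity, read by CCK-8 assay, with a stated time of 72 h, tested at 2 uM (a lower number here means a weaker effect, a higher number a stronger effect of the compound at the concentration tested), compound 3 gives 39.4%. Compound 2, with 45.7%, lies within the scatter of compound 3, so the two cannot be told apart on these numbers. Compound 1, with 63.5%, stands higher than compound 3 by a gap beyond the scatter. No two of the three differ in one place only, so no single step can be read off among them.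

Compound 4 `Nc1ccccc1NC(=O)c1ccc(CSC(=S)N2CCN(c3ncccn3)CC2)cc1` differs from compound 3 in one place: pyrimidin-2-yl in place of 4-methoxyphenyl on an amine nitrogen in a ring. Going by the values given here, nothing among the measured compounds shows what this swap does, since the three vary at several points at once.

For this assay the account expects no step beyond the scatter from compound 3 to compound 4, with the estimated step of a number 3.4 percentage points lower from compound 3 to compound 4 (within the scatter). Compound 4 is therefore expected to give about 36% in this assay, in the range 22% to 50%.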

Compound 4, a percentage reported as inhibition, at one concentration (the size of the read-out at that concentration, not a potency): 52.2%
For compound 4 the middle estimate is 16.2 percentage points below the measured one, outside the stated range (above it).
By their numbers in this assay, from the lowest: compounds 3, 2 and 4 (each within the scatter of the next, the first and the last beyond it); then compound 1.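

Pyrimidin-2-yl in place of 4-methoxyphenyl on an amine nitrogen in a ring gives a number 12.8 percentage points higher from compound 3 to compound 4 (beyond the scatter) in this assay, the first single-place comparison here, and it shows that the group at this position can change the read-out. Going by these compounds alone, the swap replaces a ring of carbon only that carries a methoxy group with a smaller group whose ring has 2 hetero atoms, so this one step joins several differences. No measurement at hand bears on why the read-out changes with this swap.

The compounds shown leave open whether the step follows the ring nitrogens or the loss of the methoxy group, which an unsubstituted phenyl or a pyridin-2-yl at this place would help to separate. They also leave open how a non-aromatic group, such as a short alkyl chain, would read at this position.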